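Adding a chlorine to a soluble quinazoline-type pair

This account rests on a few compounds, and the source may have more. Where it says the series, first, only, none or still open, it means among the compounds named here.

The two measured compounds share one core and differ only in the group on one ring nitrogen. Compound 1 `CC(C)Nc1nc(NCc2ccco2)c2ccccc2n1` carries a (furan-2-yl)methyl group there, while compound 2 `CC(C)Nc1nc(NC2CCCCC2)c2ccccc2n1` carries a cyclohexyl group. In a physicochemical assay for solubility, at pH 7.4 (on this read-out higher numbers stand for higher solubility and lower numbers for lower solubility), compound 1 reaches the limit >= 30000 nM, which is a boundary of the measurement rather than an exact number. In this assay compound 2 sits at the limit <= 20000 nM, again a boundary and not a number. The step of an at least 1.5-fold lower number from compound 1 to compound 2 (0.17 log units; that floor lies within the scatter) is known only as a floor, and that floor lies within the usual scatter, so the two values cannot be ordered with confidence; see the limit of >= 30000 nM in this assay, at which 1 of the 2 values shown sits, and (the limit of <= 20000 nM in this assay, at which 1 of the 2 values shown sits).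

Compound 3 `CC(C)Nc1nc(NCc2ccco2)c2cc(Cl)ccc2n1` keeps the (furan-2-yl)methyl group of compound 1 and differs from it by chloro in place of hydrogen on an aromatic carbon. Going by the values given here, no measured step touches this part of the core, so the expectation rests on compound 1 alone, which stands at a limit. For compound 3 the expected step is an at least 2.0-fold lower number from compound 1 to compound 3 (0.30 log units; that floor lies within the scatter), a modest move to a lower number. The estimate for compound 3 in this assay is 15000 nM, with a range from 5000 nM to 40000 nM.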

Compound 3, solubility: <= 20000 nM
Compound 3 was reported as a limit; the forecaster's own chance of this, stated with the estimate: 40%; the middle value lies beyond the limit too.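

Going by these compounds alone, compound 3 gives the first reading of a change on the ring carbons of the shared core, whereas the earlier step changed only the group on a nitrogen. In this assay, within the data shown here, chloro in place of hydrogen on this aromatic carbon, meta to a fused ring and para to a fused ring, gives an at least 1.5-fold lower number from compound 1 to compound 3 (0.17 log units; that floor lies within the scatter), so this floor lies within the usual scatter and does not show that the single chlorine changes the read-out at all. The comparison cannot be sharpened, since compound 3 is known only through a limit of the assay and not through a number, and compound 1 is too: the limit of <= 20000 nM in this assay, at which 2 of the 3 values shown sit.

On these data alone, whether chloro at this carbon has a real effect, and how large it might be, stays open, since neither end of the step is an exact number. Also open, as far as these compounds go, is how a different group on the same carbon, such as an amine, a methoxy group or a carboxylic acid, would read in this assay, and whether chloro on another carbon of this ring would read the same way.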